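Carboxy to hydroxymethyl on the shared core

The source may report more compounds than this note shows. Statements on the series, on what has been measured and on what is new or still open speak of the compounds shown alone.

Compound 2 `O=C(O)COc1cccc(CC(C(=O)O)c2nc(-c3ccccc3)c(-c3ccccc3)o2)c1` gives the higher of the two numbers seen so far in a functional assay for inhibition, with Homo sapiens as the target (a lower number here means a stronger inhibitor, a higher number a weaker inhibitor), at 14000 nM. Compound 1 `CCOC(=O)/C(=C\c1cccc(OCC(=O)OC)c1)c1nc(-c2ccccc2)c(-c2ccccc2)o1` gives 2000 nM in this assay, and that gap is beyond the scatter; the two differ in several places, so nothing is read from it about any single change. Compound 3 `O=C(O)COc1cccc(CC(CO)c2nc(-c3ccccc3)c(-c3ccccc3)o2)c1` differs from compound 2 by hydroxymethyl in place of carboxy on a saturated chain carbon bound to an aromatic carbon and a saturated chain carbon. Going by the values given here, no step of this kind has been measured, so no direction is established. The step from compound 2 to compound 3 is expected to be a 1.4-fold lower number from compound 2 to compound 3 (0.15 log units; within the scatter), about the scatter or a little better. Compound 3 is expected to give 10000 nM, within 3000 nM to 40000 nM.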

Compound 3, half-maximal inhibitory concentration: 9310 nM
Compound 3: the middle estimate sits 1.1-fold (0.03 log units) above what was measured, within the range that was stated.
By their numbers in this assay, from the lowest: compound 1; then compounds 3 and 2 (each within the scatter of the next).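

In this assay, hydroxymethyl in place of carboxy on a saturated chain carbon bound to an aromatic carbon and a saturated chain carbon gives a 1.5-fold lower number from compound 2 to compound 3 (0.18 log units; within the scatter), so this exchange at this position does not move the number beyond the scatter. Going by these compounds alone, this is the first single-place step, and it rests on this one pair alone. Nothing on hand bears on the reason for this result. On these data alone, whether an aminomethyl group or a longer chain such as hydroxyethyl at this position would move the number beyond the scatter remains open.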